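Replacing the chloromethylphenyl sulfone with a cyanophenyl sulfone

The compounds below may be only part of what the source reports. "The series", "measured", "known", "first", "only" and "open" are said of these compounds alone.

Measured so far:
compound 1, `COc1ccc(S(=O)(=O)c2cnc3ccc(Cl)cc3c2N2CCC(C)CC2)cc1Cl`: 46%
compound 2, `Cc1ccc(S(=O)(=O)c2cnc3ccc(Cl)cc3c2N2CCC(C)CC2)cc1Cl`: 81%

In an assay on isolated protein for displacement of a labelled ligand from metabotropic glutamate receptor 5 (Homo sapiens), with a stated time of 60 min, tested at 1 uM (a lower number here means less inhibition, a higher number more inhibition at the concentration tested (going by the name of the read-out)), compound 1 gives 46% and compound 2 gives 81%. Among the compounds with values here, the single measured step, a number 35 percentage points higher from compound 1 to compound 2 (beyond the scatter), is the only guide available. Compound 2 therefore stands highest of the two numbers, with compound 1 as its nearest neighbour, lower by that step.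

Compound 3, `CC1CCN(c2c(S(=O)(=O)c3ccc(C#N)cc3)cnc3ccc(Cl)cc23)CC1`, is not yet measured. It differs from compound 2 in one place: 4-cyanophenyl in place of 3-chloro-4-methylphenyl on a sulfonyl sulfur. Within the data shown here, no measured step touches this change; the methyl-in-place-of-methoxy step altered a different group, so its size says nothing firm about swapping the whole 3-chloro-4-methylphenyl for 4-cyanophenyl. Without a bearing step, no direction can be expected with confidence, and a wide range is appropriate.

For compound 3 the expected value in this assay is 50%, within 15% to 85%. That estimate corresponds to a step of a number 31 percentage points lower from compound 2 to compound 3 (beyond the scatter).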

Compound 3, a percentage reported as inhibition, at one concentration (the size of the read-out at that concentration, not a potency): 31%
Compound 3: middle estimate off by 19 percentage points, on the high side; low and high end bracket the measured number.
By their numbers in this assay, from the lowest: compound 3; then compound 1; then compound 2.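

In this assay, the group on the sulfonyl sulfur matters as a whole, not just through its methyl or methoxy: 4-cyanophenyl in place of 3-chloro-4-methylphenyl gives a number 50 percentage points lower from compound 2 to compound 3 (beyond the scatter), and 4-cyanophenyl in place of 3-chloro-4-methoxyphenyl gives a number 15 percentage points lower from compound 1 to compound 3 (beyond the scatter). Both steps point down, so 4-cyanophenyl gives the lowest number of the three compounds, while the size of the drop depends on which group it replaces. No measurement shown bears on the reason for these drops.

The chlorine and the methyl or methoxy leave together as the nitrile enters, so the share of each in the drop remains unresolved. From the compounds shown here alone, how a plain phenyl or a pyridyl on the sulfonyl sulfur would read in this assay also remains open.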